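The source may report more compounds than this note shows. Statements on the series, on what has been measured and on what is new or still open speak of the compounds shown alone.

Measured compounds:
compound 1 `Cc1n[nH]c2ccc(-c3nc4cnc(N5CCN(C)CC5)cn4c3Nc3ccc(Cl)cc3)cc12`: 3510 nM
compound 2 `Cc1n[nH]c2ccc(-c3nc4cnc(N5CCN(C)CC5)cn4c3Nc3ccccc3)cc12`: "not determined" (no result reported)

In a functional assay on MV4-11 cells (Homo sapiens) for inhibition, with a stated time of 120 h (a higher number here means a weaker inhibitor, a lower number a stronger inhibitor), compound 1 gives 3510 nM. Compound 2 has no single number in this assay, so it stands nowhere on the scale shown; only its structure is known. Compound 3 `Cc1n[nH]c2ccc(-c3nc4cnc(N5CCN(C)CC5)cn4c3Nc3ccc(F)cc3Br)cc12` carries 2-bromo-4-fluorophenyl in place of phenyl on a nitrogen on an aromatic ring. Within the data shown here, with no measured step to lean on, the step from compound 2 to compound 3 in this assay cannot be sized or given a direction beyond the scatter. The nearest fixed point is compound 1 with 3510 nM. Compound 3 is therefore expected at about 3000 nM, within a range of 800 nM to 12000 nM.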

Compound 3, half-maximal inhibitory concentration: 3830 nM
Estimate against measurement, compound 3: 1.3-fold (0.11 log units) below; low and high end bracket the measured number.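

In this assay, 2-bromo-4-fluorophenyl in place of 4-chlorophenyl on a nitrogen on an aromatic ring shows as a 1.1-fold higher number from compound 1 to compound 3 (0.04 log units; within the scatter), so these two substituted phenyl groups cannot be told apart in this read-out. The step from the phenyl of compound 2 to compound 3 cannot be read, as compound 2 has no number. Nothing at hand bears on the reason for this result.

On these data alone, what the plain phenyl group gives remains open. So does whether a pyridyl ring, a cyclohexyl ring or a short alkyl chain on this nitrogen would move the number away from these values.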